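The compounds below may be only part of what the source reports. "The series", "measured", "known", "first", "only" and "open" are said of these compounds alone.

Measured compounds:
Compound 1, `CNc1nc(N)nc2c1ncn2/C=C1/CC1(CO)CO`: in an ADME assay on HFF cells (Homo sapiens) for cytotoxicity, with a stated time of 8 days (on this read-out lower numbers stand for higher toxicity in this test and higher numbers for lower toxicity in this test), compound 1 gives 265000 nM.
Compound 2, `CCCCCCCCOc1nc(N)nc2c1ncn2/C=C1/CC1(CO)CO`: in this assay compound 2 reaches only a limit, > 300000 nM.
Compound 3, `CC(C)Nc1nc(N)nc2c1ncn2/C=C1/CC1(CO)CO`: in this assay compound 3 likewise reaches only a limit, > 300000 nM.

Compound 3 therefore stands not at a number but at the limit of > 300000 nM in this assay, at which 2 of the 3 values shown sit. Its toxicity is bounded from one side only, and any step that starts from it can be read only partly.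

Compound 4, `CCCCCOc1nc(N)nc2c1ncn2/C=C1/CC1(CO)CO`, differs from compound 3 in one place: pentyloxy in place of isopropylamino on an aromatic carbon.

Going by the values given here, two measured steps bear on this exchange of an amino substituent for an alkoxy chain. Replacing methylamino by octyloxy gave an at least 1.1-fold higher number from compound 1 to compound 2 (0.05 log units; that floor lies within the scatter), and enlarging methylamino to isopropylamino gave an at least 1.1-fold higher number from compound 1 to compound 3 (0.05 log units; that floor lies within the scatter). The direct comparison of the two substituent types, a step that the two limits leave unreadable from compound 2 to compound 3, gives nothing further. Every step seen so far sits within the scatter, so no step beyond the scatter is expected here either.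

The step expected in this assay is thus a number no higher from compound 3 to compound 4 (the limit leaves the size open). Compound 4 is accordingly estimated at 300000 nM, with a range from 150000 nM to 600000 nM, and it is likely that the measurement will again report only a limit.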

Compound 4, half-maximal cytotoxic concentration: 259000 nM
The estimate for compound 4 lay 1.2-fold (0.06 log units) above the measured number, within the range that was stated.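

Compound 2 and compound 3 stop at a limit, whereas compound 4 returns a plain number in this assay, giving the alkoxy chains at this aromatic carbon their first readable value: the limit of > 300000 nM in this assay, at which 2 of the 4 values shown sit. Set against those limits, pentyloxy in place of isopropylamino gives an at least 1.1-fold lower number from compound 3 to compound 4 (0.06 log units; that floor lies within the scatter), and the shorter pentyloxy chain in place of octyloxy gives an at least 1.1-fold lower number from compound 2 to compound 4 (0.06 log units; that floor lies within the scatter); both steps are only floors, and both lie within the scatter. Going by these compounds alone, the one step between two true numbers is a 1.0-fold lower number from compound 1 to compound 4 (0.01 log units; within the scatter), so at this position the read-out does not yet separate pentyloxy from methylamino.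

Every compound shown links its substituent to this carbon through a nitrogen or an oxygen, so the outcome with a sulfur-linked chain, a chlorine or a plain hydrogen there remains open. On these data alone, it also remains open whether a ring-bearing group such as benzyloxy, or a chain longer than octyloxy, would give a step beyond the scatter in this assay.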